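Compound 2 to Compound 3: A Triazolyl Group Enters

This account rests on a few compounds, and the source may have more. Where it says the series, first, only, none or still open, it means among the compounds named here.

Measured in a functional assay on RXF 393 cells (Homo sapiens) for inhibition; a lower number here means a stronger inhibitor of growth, a higher number a weaker inhibitor of growth:
Compound 1 `C=C1C(=O)O[C@H]2[C@H]1CC/C(COC(=O)N1CCC(F)(F)CC1)=C\CC[C@@]1(C)O[C@@H]21`: 1200 nM
Compound 2 `C=C1C(=O)O[C@H]2[C@H]1CC/C(COC(=O)NCCN1CCCC1)=C\CC[C@@]1(C)O[C@@H]21`: 4080 nM

Of the two, compound 2 has the higher number at 4080 nM, which makes it the weaker inhibitor of growth in this assay. Compound 3 `C=C1C(=O)O[C@H]2[C@H]1CC/C(COC(=O)Nc1n[nH]c(SC)n1)=C\CC[C@@]1(C)O[C@@H]21` has not yet been measured. It carries 5-(methylsulfanyl)-1H-1,2,4-triazol-3-yl in place of 2-(pyrrolidin-1-yl)ethyl on an amide-type nitrogen. For the measured compounds named here, one measured step bears on this change, a 3.4-fold higher number from compound 1 to compound 2 (0.53 log units; beyond the scatter), and it also alters the group on the carbonyl carbon. That step is modest but beyond the scatter. Going by the values given here, no measured compound carries this triazolyl group, so the direction is uncertain. A modest move towards compound 1 at 1200 nM is the expectation. The expected step is a 2.3-fold lower number from compound 2 to compound 3 (0.36 log units; beyond the scatter). For compound 3 the estimated value is 1800 nM, with an expected range of 500 nM to 6000 nM.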

Compound 3, concentration for 50% growth inhibition: 900 nM
Compound 3: the middle estimate sits 2.0-fold (0.30 log units) above what was measured; the range from low to high includes it.
By their numbers in this assay, from the lowest: compounds 3 and 1 (each within the scatter of the next); then compound 2.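

In this assay, putting 5-(methylsulfanyl)-1H-1,2,4-triazol-3-yl in place of 2-(pyrrolidin-1-yl)ethyl on the amide-type nitrogen gives a 4.5-fold lower number from compound 2 to compound 3 (0.66 log units; beyond the scatter), so this position accepts a five-membered aromatic ring with 3 hetero atoms and the number falls with it. The second step, a 1.3-fold lower number from compound 1 to compound 3 (0.12 log units; within the scatter), puts the (5-(methylsulfanyl)-1H-1,2,4-triazol-3-yl)amino group level with 4,4-difluoropiperidin-1-yl on the carbonyl carbon, so the amide hydrogen, present in both compound 2 and compound 3, does not by itself set the higher number of compound 2. No measurement in hand accounts for these differences.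

The compounds shown leave open whether the lower number belongs to the triazole ring or to its methylsulfanyl group. A methyl or a free amine in place of methylsulfanyl, or a phenyl ring in place of the triazole, would separate the two.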